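Swapping a Small Ring for a Branched Chain

The source may hold more compounds than are shown below. What is called first, only, known or untested is meant among the compounds shown, and "the series" means these compounds.

Of the compounds shown here, three share a core and have been tested in an assay for inhibition of leukotriene C4 synthase (Homo sapiens), read by LC-MS, with stated times of 15 min and 30 min; a higher number here means a weaker inhibitor, a lower number a stronger inhibitor. Compound 1 `COc1cc(N(CC(C)C)c2cccc(C(F)(F)F)c2)cnc1C(=O)[C@H]1C[C@@H]1C(=O)O` gives 4.74 nM, compound 2 `COc1cc(N(CC2CC2)c2cc(Cl)ccc2F)cnc1C(=O)[C@H]1C[C@@H]1C(=O)O` gives 3.71 nM, and compound 3 `COc1cc(N(CC2CC2)c2cc(Cl)c(F)cc2F)cnc1C(=O)[C@H]1C[C@@H]1C(=O)O` gives 1.97 nM, the lowest number of the three. For the measured compounds named here, the only single-point step among them, a 1.9-fold lower number from compound 2 to compound 3 (0.27 log units; within the scatter), is small. Compound 4 `COc1cc(N(CC(C)C)c2cc(Cl)c(F)cc2F)cnc1C(=O)[C@H]1C[C@@H]1C(=O)O` differs from compound 3 by isopropyl in place of cyclopropyl on a saturated chain carbon bound to a nitrogen on an aromatic ring, read one bond further out as cyclopropylmethyl to isobutyl. Going by the values given here, no measured pair isolates this change; compound 1 carries isobutyl but also a different aryl group, so its value cannot be attributed to the chain alone. The change is therefore expected to produce no step beyond the scatter, a 1.3-fold higher number from compound 3 to compound 4 (0.12 log units; within the scatter). Compound 4 is estimated at 2.6 nM, with a range from 1.2 nM to 6 nM.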

Compound 4, half-maximal inhibitory concentration in the leukotriene C4 synthase assay: 0.7 nM
Beside the measured number, compound 4's estimate is 3.7-fold (0.57 log units) above it; measured number outside the range, below it.
By their numbers in the leukotriene C4 synthase assay, from the lowest: compound 4; then compounds 3, 2 and 1 (each within the scatter of the next, the first and the last beyond it).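

In the leukotriene C4 synthase assay, the change from cyclopropylmethyl to isobutyl, now seen with the aryl group held constant, gives a 2.8-fold lower number from compound 3 to compound 4 (0.45 log units; beyond the scatter), with compound 3 at 1.97 nM and compound 4 at 0.7 nM, so opening this ring has a measurable effect here. With isobutyl held constant, changing the aryl group gives a 6.8-fold lower number from compound 1 to compound 4 (0.83 log units; beyond the scatter). In a physicochemical assay for lipophilicity, read by LC-MS, in phosphate buffer, measured as octanol-water partition, at pH 7.4 (on this read-out lower numbers stand for lower lipophilicity and higher numbers for higher lipophilicity), compound 3 gives 1.1 and compound 4 gives 1.3; the chain change gives a number 0.20 log units higher from compound 3 to compound 4 (within the scatter), and nothing available accounts for the step in the leukotriene C4 synthase assay.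

Going by these compounds, whether a longer chain or a chain carrying an amine would give a still lower number stays open. So does whether the chain step would carry over to the 3-(trifluoromethyl)phenyl group of compound 1.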